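From 2-bromophenoxy to 3-bromophenoxy

The compounds below may be only part of what the source reports. "The series", "measured", "known", "first", "only" and "open" are said of these compounds alone.

- Compound 1 `NC1=NC2(CCOCC2)N(OCCCOc2cccc(Cl)c2Cl)C(N)=N1`: 140 nM
- Compound 2 `NC1=NC2(CCOCC2)N(OCCCOc2ccccc2Cl)C(N)=N1`: 1430 nM
- Compound 3 `NC1=NC2(CCOCC2)N(OCCCOc2ccccc2Br)C(N)=N1`: 910 nM

In a functional assay on MDA-MB-231 cells (Homo sapiens) for antiproliferative activity, read by MTT assay, with a stated time of 72 h (on this read-out higher numbers stand for weaker inhibition and lower numbers for stronger inhibition), the values put compound 3 close to one neighbour, with a 1.6-fold lower number from compound 2 to compound 3 (0.20 log units; within the scatter), and well apart from the other, with a 6.5-fold higher number from compound 1 to compound 3 (0.81 log units; beyond the scatter). Compound 4 `NC1=NC2(CCOCC2)N(OCCCOc2cccc(Br)c2)C(N)=N1` has the same atoms as compound 3, joined differently: 3-bromophenyl in place of 2-bromophenyl on an oxygen on a saturated carbon. In short, 3-bromophenyl replaces 2-bromophenyl on an oxygen on a saturated carbon. For the measured compounds named here, no measured pair shows this move directly. The closest guide is a 10-fold higher number from compound 1 to compound 2 (1.01 log units; beyond the scatter), where the chloro lost sits on the ring carbon that holds the bromo in compound 4. That large step hints at some gain, but compound 4 keeps only one halogen. The expected change is therefore modest, toward stronger inhibition: a 2.3-fold lower number from compound 3 to compound 4 (0.36 log units; beyond the scatter). Compound 4 is estimated at 400 nM, with a range of 100 nM to 1500 nM.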

Compound 4, half-maximal inhibitory concentration: 400 nM
For compound 4 middle estimate and measured number coincide at the digits printed, and the stated range covers the measured number.
By their numbers in this assay, from the lowest: compound 1; then compound 4; then compounds 3 and 2 (each within the scatter of the next).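

Moving the bromine from 2-bromophenyl to 3-bromophenyl leaves the atoms unchanged, yet in this assay it gives a 2.3-fold lower number from compound 3 to compound 4 (0.36 log units; beyond the scatter), so the halogen's place on this ring matters by itself. One halogen as 3-bromophenyl also improves on 2-chlorophenyl, with a 3.6-fold lower number from compound 2 to compound 4 (0.55 log units; beyond the scatter), but falls short of 2,3-dichlorophenyl, with a 2.9-fold higher number from compound 1 to compound 4 (0.46 log units; beyond the scatter). Nothing available explains these shifts. Still open, from the compounds shown here alone, is how 3-chlorophenyl or 3-methoxyphenyl would compare with 3-bromophenyl on this oxygen, and whether a longer chain would change the picture.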